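A few compounds are considered here, and "the series" means these few. Any claim that something is new, unique, unknown or untested is made for them only; others in the source may bear on it.

Among the compounds with values here, in an ADME assay on MT4 cells (Homo sapiens) for cytotoxicity, read by MTT assay, with a stated time of 96 h (on this read-out higher numbers stand for lower toxicity in this test and lower numbers for higher toxicity in this test), two compounds carry numbers so far. Compound 1 (`O=[N+]([O-])c1ccc(-c2nc3ccccc3[nH]2)c([N+](=O)[O-])c1`) gives 7000 nM and compound 2 (`Oc1ccc(-c2nc3cc(C(F)(F)F)ccc3[nH]2)cc1`) gives 17000 nM in the same read-out. Compound 2 therefore holds the higher of the two numbers, and its gap to compound 1 lies beyond the scatter. These two compounds differ in more than one place, so their gap cannot be tied to any single change.

Compound 3 (`O=[N+]([O-])c1ccc(-c2nc3cc(C(F)(F)F)ccc3[nH]2)cc1`) departs from compound 2 in one place, with nitro in place of hydroxy on an aromatic carbon, para to a large group (nitro in place of hydroxy on an aromatic carbon). Within the data shown here, no measured pair isolates this change. Among the measured compounds shown here, the only nitro-bearing compound with a number, compound 1 at 7000 nM, lies lower, which gives weak support for a downward direction. The expected result is a small move toward a lower number, estimated as a 1.4-fold lower number from compound 2 to compound 3 (0.15 log units; within the scatter) and not clearly beyond the scatter. In this assay the estimated value for compound 3 is 12000 nM with an expected range from 4500 nM to 40000 nM on present evidence.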

Compound 3, half-maximal cytotoxic concentration: 6000 nM
Compound 3: the middle estimate sits 2.0-fold (0.30 log units) above what was measured; the measured number falls inside the stated range.
By their numbers in this assay, from the lowest: compounds 3 and 1 (each within the scatter of the next); then compound 2.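

In this assay, the position para to a large group now has its first reading from a change in one place: a 2.8-fold lower number from compound 2 to compound 3 (0.45 log units; beyond the scatter), a modest step beyond the scatter, with nitro in place of hydroxy. The earlier compounds shown here differed in more than one place and could not tie their gap to any single change, whereas here the rest of the structure stays the same, so the lower number belongs to this exchange on the trifluoromethyl-bearing compounds. The exchange removes a hydroxy group that counts as a hydrogen-bond donor and brings in a nitro group that counts as none, but no measurement on hand shows what in the exchange accounts for the step.

From the compounds shown here alone, a single pair gives the direction of this exchange for this one core only, so it remains open whether the same exchange would give a similar step on another core. How an amine, a carboxylic acid or a methoxy group at this position would compare with hydroxy and nitro also remains open, as does the part played by the trifluoromethyl group, which no pair among these compounds isolates.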